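Trifluoromethoxy for fluoro in a cytotoxicity series

This account rests on a few compounds, and the source may have more. Where it says the series, first, only, none or still open, it means among the compounds named here.

Compound 1, `Cc1ccc2nc(-c3ccccc3F)[nH]c(=O)c2c1`, gives > 50000 nM in a functional assay on T47D cells (Homo sapiens) for cytotoxicity, read by MTT assay, with a stated time of 2 days; on this read-out higher numbers stand for weaker inhibition and lower numbers for stronger inhibition; that is a limit of the assay, not a number.
Compound 2, `Cc1ccc2nc(-c3cccc(F)c3)[nH]c(=O)c2c1`, gives > 50000 nM in this assay, again a limit.
Compound 3, `Cc1ccc2nc(-c3cccc(OC(F)(F)F)c3)[nH]c(=O)c2c1`, gives > 50000 nM in this assay, also a limit.

Compound 3 arises from compound 2 by trifluoromethoxy in place of fluoro on an aromatic carbon, and a step that the two limits leave unreadable from compound 2 to compound 3. Compound 4, `Cc1ccc2nc(-c3ccccc3OC(F)(F)F)[nH]c(=O)c2c1`, is not yet measured; it arises from compound 1 by trifluoromethoxy in place of fluoro on an aromatic carbon, the same kind of change, though here ortho to a large group rather than meta to a large group. The difference between the cores of compound 1 and compound 2 is not broken down here. Because (the limit of > 50000 nM in this assay, at which 3 of the 3 values shown sit), the measured step gives no direction. Compound 4 is expected to give 50000 nM in this assay, most likely reported again only as a limit. For compound 4 the expected step is a number no higher from compound 1 to compound 4 (the limit leaves the size open), because compound 1 stands at > 50000 nM, a limit.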

Compound 4, half-maximal inhibitory concentration: > 50000 nM
Compound 4: a limit, no number (the forecaster's own chance of this, stated with the estimate: 85%); the middle value sits exactly at the limit.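

Compound 1 and compound 4 both give only a limit, so no step can be read between them: the limit of > 50000 nM in this assay, at which 4 of the 4 values shown sit.

What trifluoromethoxy in place of fluoro does to inhibition in this assay stays open: the compounds shown give no number to compare.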